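The source may report more compounds than this note shows. Statements on the series, on what has been measured and on what is new or still open speak of the compounds shown alone.

Compound 1 `CC1(C)CC(OC(=O)CN2CN(c3ccccc3)C3(CCN(C(=O)c4ccc(C(C)(C)C)cc4)CC3)C2=O)CC(C)(C)N1` gives the lower of the two numbers measured in an assay on HEK293 cells for displacement of a labelled ligand from NPC1-like intracellular cholesterol transporter 1 (Homo sapiens) (on this read-out lower numbers stand for stronger inhibition and higher numbers for weaker inhibition), at 1300 nM. Compound 2 `CC(C)(C)OC(=O)NCCNC(=O)CN1CN(c2ccccc2)C2(CCN(C(=O)c3ccc(C4CCCCC4)cc3)CC2)C1=O` stands at 5500 nM, a gap beyond the scatter. Compound 3 `CC(C)(C)c1ccc(C(=O)N2CCC3(CC2)C(=O)N(CC(=O)NCCCCN)CN3c2ccccc2)cc1` is compound 1 with (4-aminobutyl)amino in place of (2,2,6,6-tetramethylpiperidin-4-yl)oxy on a carbonyl carbon. Going by the values given here, no measured pair isolates this change, and compound 2 at 5500 nM is the only other point, so the direction rests on little. A step of a 1.7-fold higher number from compound 1 to compound 3 (0.23 log units; within the scatter) of modest size toward a higher number is expected, not clearly beyond the scatter. Compound 3 is estimated at 2200 nM, within 700 nM to 7000 nM.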

Compound 3, half-maximal inhibitory concentration: 14500 nM
Compound 3: the middle estimate sits 6.6-fold (0.82 log units) below what was measured, and the stated range ends below it.
By their numbers in this assay, from the lowest: compound 1; then compound 2; then compound 3.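

The group on this carbonyl carbon is not a neutral choice in this assay: (4-aminobutyl)amino in place of (2,2,6,6-tetramethylpiperidin-4-yl)oxy gives an 11-fold higher number from compound 1 to compound 3 (1.05 log units; beyond the scatter) on an otherwise unchanged structure. The swap removes the ring and also replaces the oxygen link with a nitrogen link, so this single step covers both differences. No measurement on hand accounts for the step. Which difference carries the step stays open. Still unresolved is where (2,2,6,6-tetramethylpiperidin-4-yl)amino, which keeps the ring on a nitrogen link, or (4-aminobutyl)oxy, which keeps the chain on an oxygen link, would fall.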